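Ring Size Change on a Sulfonyl Group and Liver Cell Tolerance

The compounds below may be only part of what the source reports. "The series", "measured", "known", "first", "only" and "open" are said of these compounds alone.

Compound 1 `CN1CCN(S(=O)(=O)c2ccc(-c3ccc4c(Nc5ccc(OCc6cccc(F)c6)c(Cl)c5)nccc4c3)cc2)CC1` and compound 2 `CN1CCCN(S(=O)(=O)c2ccc(-c3ccc4c(Nc5ccc(OCc6cccc(F)c6)c(Cl)c5)nccc4c3)cc2)CC1` share one core and differ only in 4-methyl-1,4-diazepan-1-yl in place of 4-methylpiperazin-1-yl on a sulfonyl sulfur. In a toxicity assay on HepG2 cells (Homo sapiens) for cytotoxicity, read by MTT assay, with a stated time of 48 h (a lower number here means that less compound is tolerated, a higher number that more compound is tolerated), compound 1 reaches only a limit of the assay, > 15 uM. In this assay compound 2 likewise stops at a limit, > 15 uM. The step that the two limits leave unreadable from compound 1 to compound 2 cannot be sized, because both values sit at the limit of > 15 uM in this assay, at which 2 of the 3 values shown sit. Compound 3 `CN1CCN(S(=O)(=O)c2ccc(-c3ccc4cnnc(Nc5ccc(OCc6cccc(F)c6)c(Cl)c5)c4c3)cc2)CC1` carries a different core, and how that core differs from the core of compound 1 is not broken down here. In this assay compound 3 gives a limit, > 5 uM, which is the limit of > 5 uM in this assay, at which 1 of the 3 values shown sits. Compound 4 `CN1CCCN(S(=O)(=O)c2ccc(-c3ccc4cnnc(Nc5ccc(OCc6cccc(F)c6)c(Cl)c5)c4c3)cc2)CC1` is not yet measured and differs from compound 3 by 4-methyl-1,4-diazepan-1-yl in place of 4-methylpiperazin-1-yl on a sulfonyl sulfur, the same change as that between compound 1 and compound 2, at the same place. Compound 4 is expected to show no more toxicity than its parent, an estimated step that the limit leaves unreadable from compound 3 to compound 4, because compound 3 gives > 5 uM and the measured step that the two limits leave unreadable from compound 1 to compound 2 gives no readable size. The estimate for compound 4 in this assay is 15 uM, with an expected range from 5 uM to 50 uM.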

Compound 4, half-maximal toxic concentration: 14 uM
Estimate against measurement, compound 4: 1.1-fold (0.03 log units) above; measured number inside the range.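

No size can be read for the change from compound 3 to compound 4, because compound 3 gives only a limit and not a number: the limit of > 5 uM in this assay, at which 1 of the 4 values shown sits.

The compounds shown leave open whether 4-methyl-1,4-diazepan-1-yl in place of 4-methylpiperazin-1-yl on a sulfonyl sulfur shifts the tolerated concentration at all in this assay, on either core.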